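The compounds below may be only part of what the source reports. "The series", "measured", "known", "first", "only" and "open" are said of these compounds alone.

Of the compounds shown here, two have been measured in a functional assay on aorta for antagonist activity at Alpha-1D adrenergic receptor (Rattus norvegicus); a lower number here means tighter binding, a higher number weaker binding. Compound 1, `COc1ccccc1N1CCN(CCCNc2nc(C)cc(C)c2C(N)=O)CC1`, gives 39.8 nM in this assay. Compound 2, `CN(C)C(=O)c1cccnc1NCCCN1CCN(c2ccccc2C#N)CC1`, gives 10 nM, the lower of the two numbers; the gap up to compound 1 lies beyond the usual scatter, so compound 2 binds more tightly than compound 1.

The next compound, compound 3, `COc1cc(C)ccc1N1CCN(CCCNc2ncccc2C(=O)N(C)C)CC1`, has not yet been measured in this assay. It is built from compound 2 by one change: 2-methoxy-4-methylphenyl in place of 2-cyanophenyl on an amine nitrogen in a ring. Going by the values given here, no measured pair shows this change on its own, so its effect is not known from the data. Among the compounds with values here, the only hint is that compound 1 gives a higher number than compound 2. A modest weakening is expected, a step of a 2.0-fold higher number from compound 2 to compound 3 (0.30 log units; within the scatter). For compound 3 the expected value in this assay is 20 nM, with a likely range from 6 nM to 63 nM.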

Compound 3, dissociation constant: 39.8 nM
The estimate for compound 3 lay 2.0-fold (0.30 log units) below the measured number, and the stated range covers the measured number.
By their numbers in this assay, from the lowest: compound 2; then compounds 1 and 3 (each within the scatter of the next).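

Going by these compounds alone, only one place changes here, so the swap of 2-cyanophenyl for 2-methoxy-4-methylphenyl on an amine nitrogen in a ring now has a direct reading: a 4.0-fold higher number from compound 2 to compound 3 (0.60 log units; beyond the scatter) in this assay. The earlier compounds shown here could only hint at this, and the pair now shows that the group at this position matters for binding, with the nitrile-bearing group giving the tighter binding of the two, though the size of the step is modest. No measurement at hand explains why the number rises.

The change removes the nitrile and brings in a methoxy and a methyl group all at once, so the compounds shown leave open which of these accounts for the step. A plain phenyl group or a chlorophenyl group at this same place would help to separate those contributions.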